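The source may hold more compounds than are shown below. What is called first, only, known or untested is meant among the compounds shown, and "the series" means these compounds.

Going by the values given here, compound 3 `CN(CCC#N)C(=O)c1ccc([C@H]2[C@@H](F)[C@@H](F)C[C@@H](F)[C@H]2F)cc1` gives 8.1 10^-6 cm/s in an ADME assay on MDCK-MDR1 cells (Canis lupus familiaris) for permeability, in the apical to basolateral direction, with a stated time of 180 min (a lower number here means that the compound crosses the layer more slowly, a higher number that the compound crosses the layer faster), the highest of the three numbers measured so far. Compound 1 `O=C(c1ccc([C@H]2[C@@H](F)[C@@H](F)C[C@@H](F)[C@H]2F)cc1)N1CC(O)C1` sits nearest with 6.7 10^-6 cm/s, within the scatter of compound 3, while compound 2 `O=C(Cn1ccnc1)Nc1ccc([C@H]2[C@@H](F)[C@@H](F)C[C@@H](F)[C@H]2F)cc1` gives 0.9 10^-6 cm/s, a number that lies beyond the scatter from compound 3. Compound 4 `COCCC(=O)Nc1ccc([C@H]2[C@@H](F)[C@@H](F)C[C@@H](F)[C@H]2F)cc1` has not yet been measured; it differs from compound 3 in one place: ((2-methoxyethyl)carbonyl)amino in place of (2-cyanoethyl)(methyl)carbamoyl on an aromatic carbon. Among the compounds with values here, the only single-change step measured, a 1.2-fold higher number from compound 1 to compound 3 (0.08 log units; within the scatter), exchanged one group for another on a carbonyl carbon and stayed within the scatter, so it offers little guidance for this different kind of change. Compound 4 is expected to give 3.5 10^-6 cm/s, with a range from 1.2 10^-6 cm/s to 9 10^-6 cm/s, which would mean an expected 2.3-fold lower number from compound 3 to compound 4 (0.36 log units; beyond the scatter).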

Compound 4, apparent permeability: 18.1 10^-6 cm/s
Estimate against measurement, compound 4: 5.2-fold (0.71 log units) below; the measured number lies above the stated range.
By their numbers in this assay, from the lowest: compound 2; then compounds 1 and 3 (each within the scatter of the next); then compound 4.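

In this assay, placing ((2-methoxyethyl)carbonyl)amino on the aromatic carbon gives a 2.2-fold higher number from compound 3 to compound 4 (0.35 log units; beyond the scatter) and a 2.7-fold higher number from compound 1 to compound 4 (0.43 log units; beyond the scatter) in the second comparison, so an amide hydrogen at this position does not by itself hold the number down. Compound 2 carries that same hydrogen, yet methoxymethyl in place of 1H-imidazol-1-yl gives a 20-fold higher number from compound 2 to compound 4 (1.30 log units; beyond the scatter) and shows that the end of the chain matters far more here. Nothing measured here explains why these numbers move. From the compounds shown here alone, whether an amine or a carboxylic acid at that chain end would fall nearer compound 2 or compound 4 remains open.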